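A few compounds are considered here, and "the series" means these few. Any claim that something is new, unique, unknown or untested is made for them only; others in the source may bear on it.

Measured so far in a functional assay on MCF7 cells (Homo sapiens) for antiproliferative activity; a higher number here means a weaker inhibitor, a lower number a stronger inhibitor:
compound 1 `O=C(CCCCCCC(=O)Nc1ccc(Nc2nc(-c3cn[nH]c3)c3cc[nH]c3n2)cc1)NO`: 15600 nM
compound 2 `CCCn1cc(-c2nc(Nc3ccc(NC(=O)CCCCCCC(=O)NO)cc3)nc3[nH]ccc23)cn1`: 8200 nM
compound 3 `COCCn1cc(-c2nc(Nc3ccc(NC(=O)CCCCCCC(=O)NO)cc3)nc3[nH]ccc23)cn1`: 12200 nM

Compound 1 cannot be told apart from its two relatives in this assay. The gaps are a 1.9-fold lower number from compound 1 to compound 2 (0.28 log units; within the scatter) and a 1.3-fold lower number from compound 1 to compound 3 (0.11 log units; within the scatter), and neither is a change that can be trusted. The next compound, compound 4 `CS(=O)(=O)CCn1cc(-c2nc(Nc3ccc(NC(=O)CCCCCCC(=O)NO)cc3)nc3[nH]ccc23)cn1`, keeps the core of compound 1 and carries 2-(methylsulfonyl)ethyl in place of hydrogen on an aromatic nitrogen. For the measured compounds named here, two measured steps bear on this, since each fills that same nitrogen, one with propyl and one with 2-methoxyethyl. A third step, a 1.5-fold higher number from compound 2 to compound 3 (0.17 log units; within the scatter), compares those two groups and is also small. So far, then, no group on that nitrogen has clearly moved the number. Going by these compounds, the new group matches neither of them, and no group containing sulfur has been measured here, so this remains untested. The expected result is no shift beyond the scatter, and the estimated step is a 1.4-fold lower number from compound 1 to compound 4 (0.15 log units; within the scatter). Compound 4 is expected near 11000 nM, within a range of 5000 nM to 24000 nM.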

Compound 4, half-maximal inhibitory concentration: > 100000 nM
Compound 4 ended at the assay's limit; the forecaster's own chance of this, stated with the estimate: 5%; middle value at least 9.0-fold (0.95 log units) away from the limit.
By their numbers in this assay, from the lowest: compounds 2, 3 and 1 (each within the scatter of the next). At a limit, above all of these: compound 4.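

In this assay, this aromatic nitrogen is not indifferent to what it carries: propyl and 2-methoxyethyl stayed within the scatter of hydrogen, whereas 2-(methylsulfonyl)ethyl gives an at least 6.4-fold higher number from compound 1 to compound 4 (0.80 log units; beyond the scatter). The end of the chain matters, since methylsulfonyl in place of methoxy gives an at least 8.1-fold higher number from compound 3 to compound 4 (0.91 log units; beyond the scatter), and methylsulfonyl in place of methyl gives an at least 12-fold higher number from compound 2 to compound 4 (1.08 log units; beyond the scatter). The value of compound 4 is a limit of the assay, not a number: the limit of > 100000 nM in this assay, at which 1 of the 4 values shown sits.

The compounds shown cannot tell whether this weakening is specific to methylsulfonyl or would also appear with other groups at the end of the chain, such as an amine or a carboxylic acid. Nor do they show whether a longer chain carrying methylsulfonyl would behave the same way.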